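The source may hold more compounds than are shown below. What is called first, only, known or untested is meant among the compounds shown, and "the series" means these compounds.

In a functional assay on HL-60 cells (Homo sapiens) for cytotoxicity, read by luminescence and CellTiter-Glo, with a stated time of 3 days (a lower number here means a stronger inhibitor, a higher number a weaker inhibitor), compound 1 `O=C(Nc1ccc(C(F)(F)F)cc1)c1cc(Cl)ccc1O` gives 510 nM. Compound 2 `O=C(Nc1ccc(OC(F)(F)F)c(Cl)c1)c1cc(Cl)ccc1O` gives 450 nM, and these two values lie within the usual scatter of repeated measurements, so compound 2 stands level with compound 1. Compound 3 `O=C(Nc1ccc(C(F)(F)F)c(Cl)c1)c1cc(Cl)ccc1O` has not yet been measured in this assay. It has trifluoromethyl in place of trifluoromethoxy on an aromatic carbon of compound 2, at a place ortho to a chloro group: trifluoromethyl in place of trifluoromethoxy on an aromatic carbon. Going by the values given here, no measured pair of compounds shows this change alone, so its size cannot be read directly from the data. Among the compounds with values here, the only guide is that compound 1, which also carries trifluoromethyl, gives 510 nM. No step beyond the scatter is therefore expected, in either direction. The estimated step is a 1.1-fold lower number from compound 2 to compound 3 (0.03 log units; within the scatter). For compound 3, the expected value is 420 nM, within an estimated range of 190 nM to 950 nM.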

Compound 3, half-maximal inhibitory concentration: 460 nM
The estimate for compound 3 lay 1.1-fold (0.04 log units) below the measured number; measured number inside the range.
By their numbers in this assay, from the lowest: compounds 2, 3 and 1 (each within the scatter of the next).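

Going by these compounds alone, compound 3 gives the first direct reading of trifluoromethyl in place of trifluoromethoxy on this aromatic carbon, ortho to a chloro group: in this assay the exchange is a 1.0-fold higher number from compound 2 to compound 3 (0.01 log units; within the scatter), so the two groups cannot be told apart here. It also gives the first reading of chloro in place of hydrogen on an aromatic carbon, a 1.1-fold lower number from compound 1 to compound 3 (0.04 log units; within the scatter), so neither single change among these three compounds moves the number beyond the scatter. No measurement is available to explain why the values stay level.

From the compounds shown here alone, whether an amine, a carboxylic acid or a longer chain in place of trifluoromethyl would also leave the number unmoved remains open. The rest of the shared core is identical in all three compounds, so what it contributes cannot be read from them.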